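Cyano in place of ethyl on the aminophenyl arm

The source may report more compounds than this note shows. Statements on the series, on what has been measured and on what is new or still open speak of the compounds shown alone.

Compound 1 `CCc1cc(N)ccc1-c1nc2ccccc2s1` is characterised in a functional assay on MCF7 cells (Homo sapiens) for inhibition; on this read-out lower numbers stand for stronger inhibition and higher numbers for weaker inhibition. For compound 1 the assay returns only a limit, < 0.1 nM, and not a number. Compound 3 `Nc1cc(Cl)c(-c2nc3ccccc3s2)c(Cl)c1` likewise returns only a limit in this assay, < 0.1 nM. Compound 2 `Nc1cc(Br)c(-c2nc3ccccc3o2)c(Br)c1` also gives a limit, < 10 nM, which is a different one. Two of the three values sit at the limit of < 0.1 nM in this assay, at which 2 of the 3 values shown sit, and one at the limit of < 10 nM in this assay, at which 1 of the 3 values shown sits. Going by the values given here, none of the three is a number, so no step between measured compounds can be computed, and the standing of compound 1 is known only as a limit shared with compound 3.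

Compound 4 `N#Cc1cc(N)ccc1-c1nc2ccccc2s1` has not yet been measured. It differs from compound 1 by cyano in place of ethyl on an aromatic carbon, in words: cyano in place of ethyl on an aromatic carbon. Among the compounds with values here, no measured pair shows a change of this kind, so nothing fixes the size of the step. The expected step is an at least 3.0-fold higher number from compound 1 to compound 4 (0.47 log units; beyond the scatter), which could be no more than the scatter or a modest loss. With the shared core kept and the amino group retained, compound 4 is expected to give about 0.3 nM in this assay. The expected range for compound 4 runs from 0.05 nM to 3 nM. A return of only a limit for compound 4 is considered fairly likely.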

Compound 4, half-maximal inhibitory concentration: < 10 nM
Compound 4 gave a limit, no number; the forecaster's own chance of this, stated with the estimate: 35%; the middle value is on the limit's open side.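

Going by these compounds alone, compound 1 and compound 4 both return only limits in this assay, so no step between them can be read. The compounds shown leave open whether cyano in place of ethyl on an aromatic carbon raises, lowers or leaves unchanged the half-maximal inhibitory concentration in this assay.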